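Chloro on the anilino ring of compound 3

The source may hold more compounds than are shown below. What is called first, only, known or untested is meant among the compounds shown, and "the series" means these compounds.

The three measured compounds share one core. Compound 1 (`CCOC(=O)CNc1nc(Nc2ccccc2)ncc1[N+](=O)[O-]`) gives in a functional assay on MCF7 cells (Homo sapiens) for antiproliferative activity, read by MTT assay, with a stated time of 48 h (on this read-out lower numbers stand for stronger inhibition and higher numbers for weaker inhibition), only a limit of the assay, > 100000 nM. Compound 2 (`COC(=O)CN(C)c1nc(Nc2cccc(OC)c2)ncc1[N+](=O)[O-]`) gives in this assay a number, 93700 nM. Compound 3 (`CCOC(=O)CN(Cc1ccccc1)c1nc(Nc2ccccc2)ncc1[N+](=O)[O-]`) gives in this assay again only a limit, > 100000 nM. Going by the values given here, the only step between two compounds that differ in one place, a step that the two limits leave unreadable from compound 1 to compound 3, cannot be sized, since both ends are limits; the same limit is described as the limit of > 100000 nM in this assay, at which 2 of the 3 values shown sit. Compound 3 therefore stands at the edge of what this assay can report, with compound 1 beside it and compound 2 giving a number close to that edge.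

Compound 4 (`CCOC(=O)CN(Cc1ccccc1)c1nc(Nc2ccc(Cl)cc2)ncc1[N+](=O)[O-]`) differs from compound 3 by chloro in place of hydrogen on an aromatic carbon. Among the compounds with values here, no measured step in this set changes the anilino ring, so nothing among the measured compounds bears directly on this change. In this assay the step from compound 3 to compound 4 is therefore expected to be a number no higher from compound 3 to compound 4 (the limit leaves the size open), that is, nothing beyond the scatter. For compound 4 the expected value in this assay is 100000 nM, within a range from 30000 nM to 300000 nM, with a fair chance that the assay again reports only a limit.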

Compound 4, half-maximal inhibitory concentration: > 100000 nM
Compound 4 was reported as a limit; the forecaster's own chance of this, stated with the estimate: 55%; the middle value lies on the limit itself.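

In this assay compound 3 and compound 4 are both reported only as limits, so the step between them, chloro in place of hydrogen, cannot be read: the limit of > 100000 nM in this assay, at which 3 of the 4 values shown sit. The compounds shown leave open whether chloro on the anilino ring changes the read-out at all, and how far compound 3 and compound 4 lie beyond that limit.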